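Cytotoxicity of a quinoline series: swapping the aryl substituent

A few compounds are considered here, and "the series" means these few. Any claim that something is new, unique, unknown or untested is made for them only; others in the source may bear on it.

Measured compounds and their cytotoxicity readings:
compound 1 `COc1ccc(F)cc1CNCCCNc1ccnc2cc(Oc3ccc(C(C)(C)C)cc3)ccc12`: 7200 nM
compound 2 `COc1ccc(F)cc1CNCCCNc1ccnc2cc(-c3cccc4ccccc34)ccc12`: 16000 nM
compound 3 `COc1ccc(F)cc1CNCCCNc1ccnc2cc(Cc3cccc(C(F)(F)F)c3)ccc12`: 440 nM

These three share one core and differ only in the group attached on an aromatic carbon of that core. In an ADME assay on HepG2 cells (Homo sapiens) for cytotoxicity, read by luminescence, CellTiter-Glo and ATP content, with a stated time of 72 h (on this read-out higher numbers stand for an effect only at larger amounts of compound and lower numbers for an effect already at smaller amounts), compound 3 gives the lowest of the three numbers, meaning it affects the cells already at the smallest amount; compound 1 sits nearest, and compound 2 furthest. The steps leading to compound 3 are both large: a 16-fold lower number from compound 1 to compound 3 (1.21 log units; beyond the scatter) and a 36-fold lower number from compound 2 to compound 3 (1.56 log units; beyond the scatter), while between the two aryl-bearing compounds the step is only modest: a 2.2-fold higher number from compound 1 to compound 2 (0.35 log units; beyond the scatter).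

Compound 4 `COc1ccc(F)cc1CNCCCNc1ccnc2cc(Oc3cccc(N(C)C)c3)ccc12` is not yet measured. Its change from compound 3 is 3-(dimethylamino)phenoxy in place of 3-(trifluoromethyl)benzyl on an aromatic carbon. This change returns to a phenoxy-type group, as in compound 1, and leaves the benzyl group that went with the low number of compound 3. The expected step would roughly reverse the large step seen from compound 1 to compound 3. Compound 4 is therefore expected to show a higher number in this assay: an 11-fold higher number from compound 3 to compound 4 (1.06 log units; beyond the scatter). The estimate for compound 4 is 5000 nM, with a range from 1500 nM to 20000 nM.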

Compound 4, half-maximal effective concentration: 3300 nM
Compound 4: the middle estimate sits 1.5-fold (0.18 log units) above what was measured; the measured number falls inside the stated range.
By their numbers in this assay, from the lowest: compound 3; then compound 4; then compound 1; then compound 2.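

Keeping the oxygen on the core and changing only the ring it carries still moves the number in this assay: 3-(dimethylamino)phenyl in place of 4-(tert-butyl)phenyl is a modest step (a 2.2-fold lower number from compound 1 to compound 4 (0.34 log units; beyond the scatter)), so the two phenoxy groups are not interchangeable here. Compound 4 lies between the other two comparison points, with 3-(trifluoromethyl)benzyl still giving the lowest number (a 7.5-fold higher number from compound 3 to compound 4 (0.88 log units; beyond the scatter)) and naphthalen-1-yl the highest (a 4.8-fold lower number from compound 2 to compound 4 (0.69 log units; beyond the scatter)). Among these four compounds, the benzyl group of compound 3 stands apart from both phenoxy groups, though it is the only benzyl group shown.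

The data shown offer no explanation for these differences. Since the link and the ring substituent both differ between compound 3 and compound 4, a 3-(trifluoromethyl)phenoxy or 3-(dimethylamino)benzyl group would be needed to tell which of the two goes with the low number.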